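This account rests on a few compounds, and the source may have more. Where it says the series, first, only, none or still open, it means among the compounds named here.

Measured in a functional assay on the whole organism with Rattus norvegicus as the target; a higher number here means that more compound is needed for the effect, a lower number that less compound is needed:
- compound 1 `O=C(O)c1cc(-c2ccccc2)ccc1O`: 54 mg/kg
- compound 2 `O=C(O)c1cc(-c2ccc(F)cc2)ccc1O`: 14 mg/kg
- compound 3 `O=C(O)c1cc(-c2ccc(C(F)(F)F)cc2)ccc1O`: 50 mg/kg

Compound 3 belongs to the upper pair of the three numbers, and the steps that place it are a 1.1-fold lower number from compound 1 to compound 3 (0.03 log units; within the scatter) and a 3.6-fold higher number from compound 2 to compound 3 (0.55 log units; beyond the scatter).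

The next compound is compound 4 `O=C(O)c1cc(-c2ccc(I)cc2)ccc1O`, which has iodo in place of trifluoromethyl on an aromatic carbon, para to a large group (iodo in place of trifluoromethyl on an aromatic carbon).

Among the compounds with values here, no iodo compound has been measured, so only the steps at this same place bear on the change. Fluoro in place of hydrogen gave a 3.9-fold lower number from compound 1 to compound 2 (0.59 log units; beyond the scatter), while trifluoromethyl in place of hydrogen gave a 1.1-fold lower number from compound 1 to compound 3 (0.03 log units; within the scatter). These three compounds show no single trend to extend to iodo. Any shift in this assay is therefore expected to be small, leaning toward a lower number, with no step beyond the scatter.

The expected step is a 1.7-fold lower number from compound 3 to compound 4 (0.22 log units; within the scatter). For compound 4 the estimated value is 30 mg/kg, with an expected range of 10 mg/kg to 80 mg/kg.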

Compound 4, dose for half-maximal effect: 120 mg/kg
Estimate against measurement, compound 4: 4.0-fold (0.60 log units) below; the whole stated range lies below it.
By their numbers in this assay, from the lowest: compound 2; then compounds 3 and 1 (each within the scatter of the next); then compound 4.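

In this assay, within the data shown here, iodo on an aromatic carbon para to a large group is the first change at this place to give a higher number than hydrogen (a 2.2-fold higher number from compound 1 to compound 4 (0.35 log units; beyond the scatter)). It also stands apart from both fluorinated groups (a 2.4-fold higher number from compound 3 to compound 4 (0.38 log units; beyond the scatter); an 8.6-fold higher number from compound 2 to compound 4 (0.93 log units; beyond the scatter)), so the series now has three levels, with compound 2 lowest, compounds 1 and 3 within the scatter of each other, and compound 4 highest. Nothing measured here accounts for this order.

On these data alone, with only hydrogen, fluoro, trifluoromethyl and iodo at this place, it remains open where chloro, bromo, methyl or an amine would fall. As far as these compounds go, it also remains open whether the iodo step would look the same with the carboxylic acid of the shared core replaced by an amide.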